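Furan to indole on a shared core

This account rests on a few compounds, and the source may have more. Where it says the series, first, only, none or still open, it means among the compounds named here.

Compound 2 `Cc1cc(-c2ccoc2)cn2c(CSCCc3ccccc3)cnc12` is known in an ADME assay on HEL cells (Homo sapiens) for cytotoxicity, with a stated time of 3 days (on this read-out higher numbers stand for lower toxicity in this test and lower numbers for higher toxicity in this test), only as a limit: in this assay compound 2 gives > 4 ug/mL (the limit of > 4 ug/mL in this assay, at which 1 of the 3 values shown sits). Compound 4 `Cc1cc(-n2ccc3ccccc32)cn2c(CSCCc3ccccc3)cnc12` differs from it in one place: 1H-indol-1-yl in place of furan-3-yl on an aromatic carbon.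

Two measured compounds bear on this change. Compound 1 `C=Cc1ccc(-c2cc(C)c3ncc(CSCc4ccccc4)n3c2)cc1` reaches only a limit in this assay, giving >= 100 ug/mL (the limit of >= 100 ug/mL in this assay, at which 1 of the 3 values shown sits). Compound 3 `Cc1cc(-n2cccc2)cn2c(CSCc3ccccc3)cnc12` gives 20 ug/mL in this assay. Going by the values given here, the step between them, an at least 5.0-fold lower number from compound 1 to compound 3 (0.69 log units; beyond the scatter), is the one measured change at the same place of the core, and it runs towards a lower number when 1H-pyrrol-1-yl enters there. For compound 4 the entering group, 1H-indol-1-yl, likewise holds one five-membered aromatic ring with 1 hetero atom, so a downward shift from the limit of compound 2 is expected, a step that the limit leaves unreadable from compound 2 to compound 4, though that limit leaves the true size open. Compound 4 is expected to give 20 ug/mL in this assay, within 4 ug/mL to 100 ug/mL.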

Compound 4, minimum cytotoxic concentration: > 20 ug/mL
Compound 4 gave a limit, no number; the forecaster's own chance of this, stated with the estimate: 40%; the middle value sits exactly at the limit.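

In this assay, compound 2 and compound 4 are both known only as limits, and the step between them cannot be read. The compounds shown leave open whether 1H-indol-1-yl in place of furan-3-yl shifts this read-out at all, and in which direction.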